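Adding a 4-Bromophenyl Group to a Potent Acid

This account rests on a few compounds, and the source may have more. Where it says the series, first, only, none or still open, it means among the compounds named here.

Within the data shown here, in a functional assay on K562 cells (Homo sapiens) for cytotoxicity, read by trypan blue exclusion, with a stated time of 96 h (on this read-out higher numbers stand for weaker inhibition and lower numbers for stronger inhibition), compound 2 `COc1cc(OC)c(/C=C/S(=O)(=O)Nc2ccc(OC)c(NC(C)C(=O)O)c2)c(OC)c1` gives 8 nM, the lower of the two numbers so far, while compound 1 `COC(=O)C(Nc1cc(NS(=O)(=O)/C=C/c2c(OC)cc(OC)cc2OC)ccc1OC)c1ccccc1` gives 2500 nM. Compound 3 `COc1cc(OC)c(/C=C/S(=O)(=O)Nc2ccc(OC)c(NC(C(=O)O)c3ccc(Br)cc3)c2)c(OC)c1` carries 4-bromophenyl in place of methyl on a saturated chain carbon bound to a carbonyl carbon and a nitrogen on an aromatic ring. Among the measured compounds shown here, only one measured step bears on this, a 310-fold lower number from compound 1 to compound 2 (2.49 log units; beyond the scatter), and it alters more than this one group, so it is a loose guide. The expected change is a 5.0-fold higher number from compound 2 to compound 3 (0.70 log units; beyond the scatter), a moderately higher number and far smaller than that step. In this assay, compound 3 is estimated at 40 nM, with a range from 6 nM to 300 nM.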

Compound 3, half-maximal inhibitory concentration: 75 nM
Compound 3: middle estimate off by 1.9-fold (0.27 log units), on the low side; the measured number falls inside the stated range.
By their numbers in this assay, from the lowest: compound 2; then compound 3; then compound 1.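

In this assay, 4-bromophenyl in place of methyl on this saturated chain carbon gives a 9.4-fold higher number from compound 2 to compound 3 (0.97 log units; beyond the scatter), so this carbon can carry an aromatic ring at a modest cost. With an aromatic ring on this carbon in both compounds, the carboxylic acid compound still shows a 33-fold lower number from compound 1 to compound 3 (1.52 log units; beyond the scatter), although that step changes more than one group. No measurement here explains why either step has its size. Still open, going by these compounds, is whether the ring or the bromine accounts for the rise, and how a 4-chlorophenyl group or a propyl chain would read at this carbon.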